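Furan to thiophene on a nucleoside core: the next step

The source may hold more compounds than are shown below. What is called first, only, known or untested is meant among the compounds shown, and "the series" means these compounds.

Going by the values given here, compound 2, `COc1ncnc2c1c(-c1ccoc1)cn2[C@@H]1O[C@H](CO)[C@@H](O)[C@H]1O`, gives 290 nM in a functional assay on HepG2 cells (Homo sapiens) for antiproliferative activity, read by XTT assay, with a stated time of 72 h (a higher number here means a weaker inhibitor, a lower number a stronger inhibitor), the lowest of the two numbers so far, with compound 1 as its nearest neighbour at a separation within the scatter. Compound 1, `COc1ncnc2c1c(-c1ccsc1)cn2[C@@H]1O[C@H](CO)[C@@H](O)[C@H]1O`, gives 430 nM in this assay. Compound 3, `COc1ncnc2c1c(-c1cccs1)cn2[C@@H]1O[C@H](CO)[C@@H](O)[C@H]1O`, has not been measured; it differs from compound 2 by thiophen-2-yl in place of furan-3-yl on an aromatic carbon. Among the compounds with values here, the one measured step that bears on this change is a 1.5-fold lower number from compound 1 to compound 2 (0.17 log units; within the scatter), which swapped a thiophene ring for a furan ring at the same aromatic carbon and stayed within the scatter. Within the data shown here, replacing furan-3-yl with thiophen-2-yl also moves the point of attachment, and no measured pair speaks to that. Compound 3 is therefore expected to move by a 1.4-fold higher number from compound 2 to compound 3 (0.14 log units; within the scatter), a step not beyond the scatter, with an estimate of 400 nM and a range from 150 nM to 1100 nM.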

Compound 3, half-maximal inhibitory concentration: 13900 nM
Beside the measured number, compound 3's estimate is 35-fold (1.54 log units) below it; the measured number lies above the stated range.
By their numbers in this assay, from the lowest: compounds 2 and 1 (each within the scatter of the next); then compound 3.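

Keeping the thiophene ring and changing only its point of attachment, with thiophen-2-yl in place of thiophen-3-yl, gives a 32-fold higher number from compound 1 to compound 3 (1.51 log units; beyond the scatter) in this assay and so isolates the effect of attachment. Thiophen-2-yl in place of furan-3-yl gives a step of similar size, a 48-fold higher number from compound 2 to compound 3 (1.68 log units; beyond the scatter) and the earlier exchange of ring type at the same attachment point stayed within the scatter. Among these three compounds, then, this aromatic carbon responds strongly to how the ring is attached and not measurably to which of the two hetero atoms it carries. No measurement shown here explains this difference.

The compounds shown leave open whether furan-2-yl would follow thiophen-2-yl. They also leave open how a six-membered phenyl ring or an amine would behave on this carbon.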